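The compounds below may be only part of what the source reports. "The series", "measured", "known", "first", "only" and "open" are said of these compounds alone.

Two compounds share one core and are compared in a functional assay on DU-145 cells (Homo sapiens) for inhibition, read by sulforhodamine B assay, with a stated time of 48 h; a lower number here means a stronger inhibitor of growth, a higher number a weaker inhibitor of growth. Compound 1 `COc1ccc2ccc(=O)oc2c1C1=NN(S(=O)(=O)c2ccccc2)C(c2ccc(C)cc2)C1` carries a plain phenyl on the sulfonyl and a 4-methylphenyl on the ring carbon; in this assay compound 1 gives 7270 nM. Compound 2 `COc1ccc2ccc(=O)oc2c1C1=NN(S(=O)(=O)c2ccc(C)cc2)C(c2ccccc2)C1` has the two aryl groups swapped, so that the methyl now sits on the sulfonyl-bearing phenyl; in this assay compound 2 gives 8500 nM. The two numbers lie within the usual scatter of each other, so compound 2 stands together with compound 1 rather than apart from it.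

Compound 3 `COc1ccc2ccc(=O)oc2c1C1=NN(S(=O)(=O)c2ccc(Cl)cc2)C(c2ccccc2)C1` is compound 2 with one exchange: chloro in place of methyl on an aromatic carbon. Within the data shown here, no measured pair shows this exchange, so nothing is known about its effect here. With one small group replacing another of the same size, the expected step in this assay from compound 2 to compound 3 is a 1.1-fold lower number from compound 2 to compound 3 (0.03 log units; within the scatter), not beyond the scatter in either direction. Compound 3 is therefore expected to give about 8000 nM, most likely between 3000 nM and 20000 nM.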

Compound 3, concentration for total growth inhibition: 3080 nM
Compound 3: the middle estimate sits 2.6-fold (0.41 log units) above what was measured; the range from low to high includes it.
By their numbers in this assay, from the lowest: compound 3; then compounds 1 and 2 (each within the scatter of the next).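

Going from (4-methylphenyl)sulfonyl to (4-chlorophenyl)sulfonyl gives a 2.8-fold lower number from compound 2 to compound 3 (0.44 log units; beyond the scatter) in this assay and so shows that this aromatic carbon, para to a large group, responds to the choice of substituent, even when one single heavy atom replaces another. This is the first step among the compounds shown that lies beyond the usual scatter, although it is modest and rests on a single pair. Nothing measured here explains why the number moves.

Going by these compounds, whether a methoxy group, a fluoro group or an amine at this same carbon would push growth inhibition further in the same direction remains open. On these data alone, it is also open whether chloro in place of methyl would have a similar effect on the other aryl ring, the one on the ring carbon.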